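Working notes: from compound 2 to compound 4

The source may report more compounds than this note shows. Statements on the series, on what has been measured and on what is new or still open speak of the compounds shown alone.

Measured in a toxicity assay on THP-1 cells (Homo sapiens) for inhibition; on this read-out lower numbers stand for higher toxicity in this test and higher numbers for lower toxicity in this test (each entry is a limit of the assay, not a number):
- compound 1 (`COc1ccc(-c2cnc(NC(=O)c3ncc[nH]3)n2C)cc1`) (> 100000 nM)
- compound 2 (`COc1ccc(-c2cnc(NC(=O)C3CCNCC3)n2C)cc1`) (> 100000 nM)
- compound 3 (`COc1ccc(-c2cnc(NC(=O)c3cccc([N+](=O)[O-])c3)n2C)cc1`) (> 100000 nM)

Compound 2 stands at > 100000 nM as a limit and not a number. Among the compounds with values here, the series so far shows the limit of > 100000 nM in this assay, at which 3 of the 3 values shown sit, and no number. In compound 4 (`COc1ccc(-c2cnc(NC(=O)c3cnc[nH]3)n2C)cc1`) 1H-imidazol-5-yl stands in place of piperidin-4-yl on a carbonyl carbon (1H-imidazol-5-yl in place of piperidin-4-yl on a carbonyl carbon). Within the data shown here, the one measured step (a step that the two limits leave unreadable from compound 1 to compound 2) has no readable size. Compound 1, with 1H-imidazol-2-yl on that carbonyl carbon, reads > 100000 nM as a limit too. The expected change (a number no higher from compound 2 to compound 4 (the limit leaves the size open)) is therefore none beyond the scatter, in either direction. Compound 4 is estimated at 100000 nM with an expected range from 50000 nM to 200000 nM in this assay and may again report only a limit.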

Compound 4, half-maximal cytotoxic concentration: > 100000 nM
Compound 4 was reported as a limit (the forecaster's own chance of this, stated with the estimate: 90%); the middle value sits exactly at the limit.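

Compound 4 gives > 100000 nM, a limit and not a number. Its steps from compound 1 and compound 2 therefore cannot be read. The compounds shown leave open whether any group on the carbonyl carbon gives a measurable value in this assay.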